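Phenyl in Place of Hydrogen on a Weakly Cytotoxic Core

This account rests on a few compounds, and the source may have more. Where it says the series, first, only, none or still open, it means among the compounds named here.

Compound 1 `Cc1cc2c(c(=O)[nH]1)OC(C(=O)CC(C)C)O2` was examined in a functional assay on Jurkat cells (Homo sapiens) for cytotoxicity, read by WST assay, with a stated time of 48 h; on this read-out higher numbers stand for weaker inhibition and lower numbers for stronger inhibition. In this assay compound 1 gives > 50000 nM, which is a limit of the assay and not a number. Compound 2 `CC(C)CC(=O)[C@@H]1O[C@@]12C(=O)C=C(Cc1ccccc1)NC2=O` likewise returns a limit, giving > 50000 nM in this assay. Compound 3 `CC1=CC(=O)C2(OC2C(=O)CC(C)C)C(=O)N1` is the only one of the three with a measured number: in this assay compound 3 gives 8000 nM. Within the data shown here, compound 1 therefore sits at the limit of > 50000 nM in this assay, at which 2 of the 3 values shown sit, and no measured step joins it to any other compound.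

Compound 4 `CC(C)CC(=O)C1Oc2cc(Cc3ccccc3)[nH]c(=O)c2O1` has not yet been measured. It differs from compound 1 by phenyl in place of hydrogen on a saturated chain carbon bound to an aromatic carbon.

Among the measured compounds shown here, no measured pair on the core of compound 1 shows this change. Compound 2 and compound 3 share a different core; there compound 3 gives a number and compound 2 returns a limit, and nothing more can be said of that pair.

Because compound 1 already stands at the limit of > 50000 nM in this assay, at which 2 of the 3 values shown sit, the author expects the step that the limit leaves unreadable from compound 1 to compound 4 to be none beyond the scatter, with compound 4 most likely reported again only as a limit. For compound 4 in this assay the estimate is 70000 nM, within a range from 20000 nM to 250000 nM.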

Compound 4, half-maximal inhibitory concentration: > 50000 nM
Compound 4: no number, only a limit (the forecaster's own chance of this, stated with the estimate: 85%); the middle value does not contradict the limit.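

In this assay compound 4 gives > 50000 nM, which is a limit of the assay and not a number. Compound 1 also stands at a limit, so no step between compound 1 and compound 4 can be read: the limit of > 50000 nM in this assay, at which 3 of the 4 values shown sit.

The compounds shown leave open whether phenyl in place of hydrogen changes cytotoxicity on the core of compound 1 at all.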